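The compounds below may be only part of what the source reports. "The series", "measured", "known", "first", "only" and "open" are said of these compounds alone.

Four compounds from one series share a central core in which a methyl-bearing oxazole carries an aryl group and an amide bond to a piperazine; the piperazine nitrogen on the far side bears a second aryl group. Compound 1 `Cc1ccc(C)c(N2CCN(C(=O)c3oc(C)nc3-c3ccc(Cl)cc3)CC2)c1` is one of them. In a functional assay on HL-60 cells (Homo sapiens) for inhibition, read by MTT assay, with a stated time of 72 h (a lower number here means a stronger inhibitor, a higher number a weaker inhibitor), compound 1 gave "not active" (no number reported), so no single number is available for it. Compound 2 `Cc1nc(-c2ccccc2Cl)c(C(=O)N2CCN(c3cccc(Cl)c3)CC2)o1` gives 132 nM in this assay. Among the measured compounds shown here, compound 3 `Cc1nc(-c2ccccc2)c(C(=O)N2CCN(c3ccccc3F)CC2)o1` gives 147 nM in this assay, which is the highest of the two numbers known, though its gap to compound 2 lies within the scatter, so the two cannot be told apart.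

Compound 4 `Cc1ccc(C)c(N2CCN(C(=O)c3oc(C)nc3-c3ccccc3)CC2)c1` has not yet been measured. It differs from compound 3 in one place: 2,5-dimethylphenyl in place of 2-fluorophenyl on an amine nitrogen in a ring. Compound 4 carries the same 2,5-dimethylphenyl that compound 1 carries, and compound 1 was reported as "not active" (no number reported) in this assay, so a weakening is expected from compound 3 to compound 4, with a step of about a 20-fold higher number from compound 3 to compound 4 (1.31 log units; beyond the scatter). On that basis compound 4 is estimated to come in at 3000 nM in this assay, within a wide range from 600 nM to 20000 nM, and there is a real chance that no number at all is reported because compound 1 gave "not active" (no number reported).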

Compound 4, half-maximal inhibitory concentration: 31.3 nM
Beside the measured number, compound 4's estimate is 96-fold (1.98 log units) above it; measured number below the stated range.
By their numbers in this assay, from the lowest: compound 4; then compounds 2 and 3 (each within the scatter of the next).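

In this assay, putting 2,5-dimethylphenyl in place of 2-fluorophenyl on the amine nitrogen in a ring gives a 4.7-fold lower number from compound 3 to compound 4 (0.67 log units; beyond the scatter) and so shows that the aryl group at this position can shift the result by more than the usual scatter, though the step is modest. Among the compounds shown here, until now the only compound with 2,5-dimethylphenyl here was compound 1 at "not active" (no number reported) in this assay, whereas compound 4 at 31.3 nM shows that this group can go with strong inhibition, and the two differ in one place, the chlorine that compound 1 carries on the aryl group of the shared core. Nothing available on the properties of these compounds or on how they act explains the gain seen here.

As far as these compounds go, what remains open is which feature of the 2,5-dimethylphenyl group goes with the stronger result, since a single methyl on the phenyl ring, a methoxy group or a pyridine ring at this position would be needed to separate the possibilities. The compounds shown also leave open whether the chlorine on the other aryl group would have the same outcome alongside 2-fluorophenyl.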